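The compounds below may be only part of what the source reports. "The series", "measured", "known", "first", "only" and "open" are said of these compounds alone.

Measured so far in a functional assay on HEp-2 cells (Homo sapiens) for cytotoxicity, read by MTT assay, with a stated time of 72 h, tested at 2.5 ug/mL; a higher number here means more inhibition of growth at the concentration tested, a lower number less inhibition of growth:
- compound 1 `O=C1NC(=S)/C(=C/c2cccc(Cl)c2)S1`, 5.44%
- compound 2 `O=C1NC(=S)/C(=C/c2cccc(F)c2)S1`, 7.03%
- compound 3 `O=C1NC(=S)/C(=C/c2ccccc2F)S1`, 1.66%

Compound 2 has the highest of these three numbers in this assay, but its distances to the others are small: compound 1 lies lower by an amount within the scatter, and compound 3, with the fluoro moved to a different aromatic carbon, also lies lower by an amount within the scatter. None of the three halogen-bearing compounds shows growth inhibition that stands clearly apart from the others.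

Compound 4 `O=C1NC(=S)/C(=C/c2cccc(Br)c2)S1` is not yet measured. It differs from compound 2 in one place: bromo in place of fluoro on an aromatic carbon. For the measured compounds named here, the one measured step that bears on this change is a halogen swap at the same aromatic carbon, a number 1.6 percentage points higher from compound 1 to compound 2 (within the scatter), which stayed within the scatter. Exchanging one halogen for another on this ring therefore gave no step beyond the scatter in this assay, and the same is expected for the change from fluoro to bromo. The expected step is a number 1 percentage points lower from compound 2 to compound 4 (within the scatter), that is, no movement beyond the scatter. Compound 4 is estimated at 6% in this assay, with a range from -4% to 16%.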

Compound 4, percent growth inhibition at one concentration: -1.82%
The estimate for compound 4 lay 7.8 percentage points above the measured number; the measured number falls inside the stated range.
By their numbers in this assay, from the lowest: compounds 4, 3, 1 and 2 (each within the scatter of the next).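

In this assay the swap now covers three halogens at one aromatic carbon, and both new steps stay within the scatter (a number 8.9 percentage points lower from compound 2 to compound 4 (within the scatter); a number 7.3 percentage points lower from compound 1 to compound 4 (within the scatter)). The earlier compounds shown here showed only the exchange of chloro and fluoro, whereas the bromo compound shows that none of the three pairs among fluoro, chloro and bromo at this carbon gives a step beyond the scatter, although these two steps are larger than the one seen before. No measurement here bears on why the numbers for these halogens lie so close together.

On these data alone, it remains open whether a group other than a halogen at this carbon, such as an amine, a carboxylic acid or a longer chain, would give a step beyond the scatter in this assay or would leave the number where the halogen compounds lie. As far as these compounds go, it also remains open whether chloro or bromo on the aromatic carbon that carries the fluoro in compound 3 would behave as the fluoro does there, and whether the shared core supports clear growth inhibition with any group on this ring.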